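From 3-bromophenyl to cyclopropyl on a shared core

This account rests on a few compounds, and the source may have more. Where it says the series, first, only, none or still open, it means among the compounds named here.

Of the compounds shown here, three have numbers so far in a functional assay on MDA-MB-231 cells (Homo sapiens), read by microscopy and transwell migration, with a stated time of 24 h (on this read-out higher numbers stand for weaker inhibition and lower numbers for stronger inhibition), and they span a wide gap. Compound 3 (`Cn1c(-c2cccc(Br)c2)cs/c1=N\C(=O)c1ccccc1`) gives 302 nM and lies within the scatter of compound 1 (`CCCCn1c(-c2ccc(C)cc2C)cs/c1=N\C(=O)c1ccccc1`) at 196 nM so these two cannot be told apart. Compound 2 (`O=C(Nc1nc(-c2cccc(Br)c2)cs1)c1ccccc1`) reads 10000 nM which is much weaker inhibition than compound 3 shows, a gap well beyond the scatter.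

Compound 4 (`Cn1c(C2CC2)cs/c1=N\C(=O)c1ccccc1`) has not been measured yet. It carries cyclopropyl in place of 3-bromophenyl on an aromatic carbon. For the measured compounds named here, no measured pair changes this group alone, so the data give no direct guide to the size of the step. The expectation rests on compound 3 at 302 nM and compound 1 at 196 nM as both hold a six-membered aromatic ring of carbon only at this place, and cyclopropyl does not. Compound 2 holds such a ring too, yet gives 10000 nM in this assay so that ring alone does not settle the matter. The expected change is a 3.3-fold higher number from compound 3 to compound 4 (0.52 log units; beyond the scatter) and it is expected to point toward weaker inhibition, beyond the scatter but with wide uncertainty. The estimated value for compound 4 is 1000 nM (range 200 nM to 6000 nM).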

Compound 4, half-maximal inhibitory concentration: 104 nM
Estimate against measurement, compound 4: 9.6-fold (0.98 log units) above, outside the stated range (below it).
By their numbers in this assay, from the lowest: compounds 4, 1 and 3 (each within the scatter of the next, the first and the last beyond it); then compound 2.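

In this assay, replacing 3-bromophenyl with cyclopropyl gives a 2.9-fold lower number from compound 3 to compound 4 (0.46 log units; beyond the scatter), a modest step toward stronger inhibition that lies beyond the scatter. This shows that the position, on an aromatic carbon next to the ring nitrogen, does not require a six-membered aromatic ring of carbon only: a three-membered non-aromatic ring, with 3 heavy atoms in place of 7, not only keeps the inhibition but improves on it. No measurement on hand explains why this exchange strengthens inhibition, and a single step cannot supply that explanation.

Several things changed together in this step: the size of the group, the aromatic ring and the bromine, so a plain phenyl, a cyclobutyl or an open isopropyl group at this place would be needed to begin separating them. As far as these compounds go, it also remains open whether the gain from cyclopropyl would carry over to a compound with a longer chain, such as butyl, in place of the neighbouring methyl group, or whether a group such as an amine would be accepted at this position.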